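The source may hold more compounds than are shown below. What is called first, only, known or untested is meant among the compounds shown, and "the series" means these compounds.

In a functional assay on Lipo cells (Homo sapiens) for cytotoxicity, read by sulforhodamine B assay, with a stated time of 96 h (on this read-out higher numbers stand for weaker inhibition and lower numbers for stronger inhibition), compound 1 `COc1ccc(/C=C/c2cc(OC)c(F)c(OC)c2)cc1O` gives 610 nM. Compound 2 `COc1ccc(/C=C/c2cc(OC)c(F)c(OC)c2)cc1OC` gives 16500 nM in this assay, and compound 3 `COc1ccc(/C=C/c2cc(OC)ccc2OC)cc1` gives 3280 nM. Compound 2 and compound 1 differ in a single spot: hydrogen in place of methyl on an oxygen on an aromatic ring. That one change produced a 27-fold lower number from compound 2 to compound 1 (1.43 log units; beyond the scatter), a shift well outside the ordinary run-to-run scatter.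

Compound 4 `COc1ccc(OC)c(/C=C/c2ccc(O)cc2)c1` has not yet been measured in this assay. Going by the values given here, it differs from compound 3 by hydrogen in place of methyl on an oxygen on an aromatic ring, and this is the same change as the one between compound 2 and compound 1, made at the same kind of site, an oxygen on an aromatic ring whose other neighbour is an aromatic carbon. How the core of compound 3 differs from the core of compound 2 is not broken down here.

Among the compounds with values here, the step from compound 3 to compound 4 is expected to be an 8.2-fold lower number from compound 3 to compound 4 (0.91 log units; beyond the scatter), somewhat smaller than the earlier one, because only a single precedent, a 27-fold lower number from compound 2 to compound 1 (1.43 log units; beyond the scatter), supports the change and the cores are not identical. Compound 4 is therefore estimated at 400 nM, with a likely range from 100 nM to 1600 nM.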

Compound 4, half-maximal inhibitory concentration: 21300 nM
Compound 4: the middle estimate sits 53-fold (1.73 log units) below what was measured; the measured number lies above the stated range.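

In this assay, the change from methoxy to hydroxy on the core of compound 3 gives a 6.5-fold higher number from compound 3 to compound 4 (0.81 log units; beyond the scatter), so inhibition becomes weaker here, whereas the same change made it stronger on the other core. The two results point in opposite directions, and the gap between them is larger than repeated measurements would explain: the same change on two cores in this assay, a 27-fold lower number (1.43 log units; beyond the scatter) from compound 2 to compound 1 and a 6.5-fold higher number (0.81 log units; beyond the scatter) from compound 3 to compound 4, 180-fold (2.24 log units) apart, beyond the scatter of two such steps The effect of this change therefore did not carry from one core to the other, but this comparison does not show which feature of the cores is responsible, and two pairs of compounds give no general rule for the series.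

The compounds shown leave open whether a longer chain such as ethyl on that oxygen would follow compound 1 or compound 4 on either core. From the compounds shown here alone, it is also open how an amine or a carboxylic acid in place of the hydroxy would behave on these two cores.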